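A few compounds are considered here, and "the series" means these few. Any claim that something is new, unique, unknown or untested is made for them only; others in the source may bear on it.

Two compounds of the series carry numbers in a functional assay on T47D cells (Homo sapiens) for cytotoxicity, read by CCK-8 assay, with a stated time of 4 days (on this read-out lower numbers stand for stronger inhibition and higher numbers for weaker inhibition), so far. Compound 1 `Oc1ccc(-c2cc(-c3cccc(O)c3)nc(-c3cccc(O)c3)c2)cc1` gives 2230 nM in this assay. Compound 2 `Oc1cccc(-c2cc(-c3cccc(O)c3)nc(-c3ccccc3O)c2)c1` gives 50000 nM in this assay, the higher of the two numbers, and its gap to compound 1 lies beyond the usual scatter. Compound 3 `Oc1cccc(-c2cc(-c3cccc(O)c3)nc(-c3cccc(O)c3)c2)c1` remains to be measured; against compound 2 the change is 3-hydroxyphenyl in place of 2-hydroxyphenyl on an aromatic carbon. Because compound 1 gives 2230 nM while carrying two 3-hydroxyphenyl groups, a downward step well beyond the scatter is expected, a 17-fold lower number from compound 2 to compound 3 (1.22 log units; beyond the scatter). The estimate for compound 3 in this assay is 3000 nM, within 800 nM to 12000 nM.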

Compound 3, half-maximal inhibitory concentration: 2050 nM
The estimate for compound 3 lay 1.5-fold (0.17 log units) above the measured number, and the stated range covers the measured number.
By their numbers in this assay, from the lowest: compounds 3 and 1 (each within the scatter of the next); then compound 2.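

In this assay, 3-hydroxyphenyl in place of 2-hydroxyphenyl next to the ring nitrogen gives a 24-fold lower number from compound 2 to compound 3 (1.39 log units; beyond the scatter), a large step from a change that only relocates the hydroxyl group within the same group of atoms. By contrast, swapping the 4-hydroxyphenyl group for a 3-hydroxyphenyl group gives a 1.1-fold lower number from compound 1 to compound 3 (0.04 log units; within the scatter), so these two placements are not separated here. Nothing available accounts for the large step. Still open, from the compounds shown here alone, is whether 2-hydroxyphenyl at another ring position gives a similar step, and how an amine or a carboxylic acid in place of the hydroxyl group would read out.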